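Aryl swap on the shared core: pyridyl for chlorophenyl

The compounds below may be only part of what the source reports. "The series", "measured", "known", "first", "only" and "open" are said of these compounds alone.

Within the data shown here, compound 3 `Cc1cc(C#N)cc(C)c1Oc1nc(Nc2ccc(C#N)cc2)ncc1-c1ccc(Cl)cc1` stands highest of the three numbers so far in an ADME assay on MT4 cells (Homo sapiens) for cytotoxicity, read by MTT assay, with a stated time of 5 days (on this read-out lower numbers stand for higher toxicity in this test and higher numbers for lower toxicity in this test), where compound 3 gives 72600 nM. Compound 1 `Cc1cc(C)cc(-c2cnc(Nc3ccc(C#N)cc3)nc2Oc2c(C)cc(C#N)cc2C)c1` gives 39000 nM and compound 2 `Cc1ccc(-c2cnc(Nc3ccc(C#N)cc3)nc2Oc2c(C)cc(C#N)cc2C)cc1` gives 26100 nM. Compound 4 `Cc1cc(C#N)cc(C)c1Oc1nc(Nc2ccc(C#N)cc2)ncc1-c1cccnc1` is not yet measured; it differs from compound 3 by pyridin-3-yl in place of 4-chlorophenyl on an aromatic carbon. All three measured steps vary this same aryl group: a 1.5-fold lower number from compound 1 to compound 2 (0.17 log units; within the scatter), a 1.9-fold higher number from compound 1 to compound 3 (0.27 log units; within the scatter), a 2.8-fold higher number from compound 2 to compound 3 (0.44 log units; beyond the scatter). Only one of them reaches beyond the scatter, and that one is modest, so the change to compound 4 is expected to bring no step beyond the scatter in this assay, estimated as a 1.2-fold lower number from compound 3 to compound 4 (0.08 log units; within the scatter). Compound 4 is therefore estimated at 60000 nM, with a range from 25000 nM to 150000 nM.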

Compound 4, half-maximal cytotoxic concentration: 13500 nM
For compound 4 the middle estimate is 4.4-fold (0.65 log units) above the measured one, and the stated range ends above it.
By their numbers in this assay, from the lowest: compounds 4, 2, 1 and 3 (each within the scatter of the next, the first and the last beyond it).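

Among these compounds, in (this assay) this position responds to the aryl group more than the earlier compounds showed: pyridin-3-yl, the only group here with a ring hetero atom and a hydrogen-bond acceptor, gives the largest step so far (a 5.4-fold lower number from compound 3 to compound 4 (0.73 log units; beyond the scatter)) and a smaller one beyond the scatter (a 2.9-fold lower number from compound 1 to compound 4 (0.46 log units; beyond the scatter)). Against 4-methylphenyl the same change stays within the scatter (a 1.9-fold lower number from compound 2 to compound 4 (0.29 log units; within the scatter)), so compound 4 does not separate from compound 2. Nothing measured here accounts for these steps.

On these data alone, whether the ring nitrogen's place matters, as in pyridin-4-yl, remains open. So does whether pyrimidin-5-yl or an aminopyridinyl group would follow compound 4 or compound 3.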